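Working notes: acetyl in place of dimethylamino

The source may report more compounds than this note shows. Statements on the series, on what has been measured and on what is new or still open speak of the compounds shown alone.

In a functional assay on A549 cells (Homo sapiens) for inhibition, read by CCK-8 assay, with a stated time of 48 h (on this read-out higher numbers stand for weaker inhibition and lower numbers for stronger inhibition), compound 1 (`COc1cc(-c2ccnc3cc(-c4ccc5cc[nH]c5c4)nn23)cc(OC)c1OC`) gives 170 nM, and compound 2 (`COc1cc(-c2ccnc3cc(-c4ccc(N(C)C)cc4)nn23)cc(OC)c1OC`) gives 1100 nM, the higher of the two numbers. Compound 3 (`COc1cc(-c2ccnc3cc(-c4ccc(C(C)=O)cc4)nn23)cc(OC)c1OC`) carries acetyl in place of dimethylamino on an aromatic carbon, para to a large group: acetyl in place of dimethylamino on an aromatic carbon. Among the compounds with values here, the only measured step, a 6.5-fold higher number from compound 1 to compound 2 (0.81 log units; beyond the scatter), is modest and involves no acetyl, so it offers a rough size but no direction. In this assay, a change within the scatter, if anything upward, is expected: the estimated step is a 1.4-fold higher number from compound 2 to compound 3 (0.13 log units; within the scatter). The estimate for compound 3 is 1500 nM, with an expected range of 450 nM to 5000 nM.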

Compound 3, half-maximal inhibitory concentration: 4100 nM
Compound 3: the middle estimate sits 2.7-fold (0.44 log units) below what was measured; measured number inside the range.
By their numbers in this assay, from the lowest: compound 1; then compound 2; then compound 3.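

In this assay, the aromatic carbon para to a large group responds to the exchange of dimethylamino for acetyl: a 3.7-fold higher number from compound 2 to compound 3 (0.57 log units; beyond the scatter) is a step beyond the scatter, so this position is not indifferent to the group it carries. Measured against the 1H-indol-6-yl of compound 1, the 4-acetylphenyl group gives a 24-fold higher number from compound 1 to compound 3 (1.38 log units; beyond the scatter), a large step that widens the gap already seen with 4-(dimethylamino)phenyl. No measurement at hand explains why the number rises with this change.

Open, as far as these compounds go, is how a primary amine, a carboxylic acid or a longer chain in place of acetyl would read at this carbon. Also open, from the compounds shown here alone, is whether a methoxy group here would come any closer to compound 1.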